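This account rests on a few compounds, and the source may have more. Where it says the series, first, only, none or still open, it means among the compounds named here.

Compound 1 `N#Cc1cc(F)cc(C(=O)Nc2ccccc2Cl)c1` and compound 2 `N#Cc1cc(F)cc(C(=O)Nc2cccc(Cl)c2)c1` share a benzamide core and differ only in where a chlorine sits on the aniline ring. In an in vitro functional assay on HEK293-A cells for antagonist activity at metabotropic glutamate receptor 5 (Rattus norvegicus), read by calcium flux (a higher number here means a weaker inhibitor, a lower number a stronger inhibitor), compound 1 gives only a limit of > 30000 nM, not a number. Compound 2 gives 45 nM in this assay, the only number shown, so it stands alone as the single measured point against which a new analogue can be judged. Compound 3 `N#Cc1cccc(NC(=O)c2cc(F)cc(C#N)c2)c1` keeps the same core and carries cyano in place of chloro on an aromatic carbon. Within the data shown here, no step between two measured compounds is available to calibrate this swap. The expectation is a change of a 1.5-fold lower number from compound 2 to compound 3 (0.18 log units; within the scatter) in this assay, small enough that it could fall within the usual scatter, leaning toward a somewhat stronger inhibitor. Compound 3 is therefore estimated at 30 nM in this assay, with a likely range from 8 nM to 120 nM.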

Compound 3, half-maximal inhibitory concentration: 489 nM
Compound 3: the middle estimate sits 16-fold (1.21 log units) below what was measured, and the stated range ends below it.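

In this assay, among these compounds, this is the first step that can be read between two measured compounds, with cyano in place of chloro on an aromatic carbon, meta to a large group: an 11-fold higher number from compound 2 to compound 3 (1.04 log units; beyond the scatter). The step shows that this position does not treat these two groups as interchangeable, although compound 3 remains a measurable inhibitor with a real number. Compound 1 is the only one here held at a limit rather than a number: the limit of > 30000 nM in this assay, at which 1 of the 3 values shown sits.

With only chloro and cyano compared at this position, the compounds shown cannot tell whether the weaker result goes with the extra heavy atom, the triple bond or the added hydrogen-bond acceptor. Going by these compounds, it also stays open whether bromo, methyl or methoxy in the same place would land nearer compound 2 or compound 3.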